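A few compounds are considered here, and "the series" means these few. Any claim that something is new, unique, unknown or untested is made for them only; others in the source may bear on it.

Measured compounds in the series:
compound 1, `COC(=O)c1cc2c(cc1Cl)SC(N(N(C)C)S(=O)(=O)c1ccc(Cl)cc1)=NS2(=O)=O`: 8700 nM
compound 2, `CCOC(=O)c1cc2c(cc1Cl)SC(N(c1ccc(OC)cc1)S(=O)(=O)c1ccc(Cl)cc1Cl)=NS2(=O)=O`: 2400 nM
compound 3, `CCOC(=O)c1cc2c(cc1Cl)SC(N(c1ccccc1)S(=O)(=O)c1ccc(Cl)cc1)=NS2(=O)=O`: 9800 nM

All three share the same core and have been run in a functional assay on MCF7 cells (Homo sapiens) for cytotoxicity, with a stated time of 96 h; a lower number here means a stronger inhibitor of growth, a higher number a weaker inhibitor of growth. Compound 1 stands second highest of the three numbers. Its nearest neighbour is compound 3, whose value differs from that of compound 1 by a margin within the scatter, so no order between compound 1 and compound 3 is claimed. Compound 2 lies furthest away, with a lower number than compound 1 by a margin beyond the scatter. For the measured compounds named here, no two measured compounds differ in one place, so no isolated step is available from the measured set.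

Compound 4, `Cc1cc2c(cc1Cl)SC(N(N(C)C)S(=O)(=O)c1ccc(Cl)cc1)=NS2(=O)=O`, is not yet measured in this assay. It differs from compound 1 as follows.

methyl in place of methoxycarbonyl on an aromatic carbon

Going by the values given here, no measured pair shows what this change does to the number in this assay, so the expectation rests on the narrow spread of the three measured values and on the starting point of compound 1. The expected step is a 1.1-fold higher number from compound 1 to compound 4 (0.06 log units; within the scatter), which is estimated to stay within the scatter, leaning if anything toward a higher number. Compound 4 is estimated at 10000 nM, with a range from 3500 nM to 30000 nM.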

Compound 4, concentration for 50% growth inhibition: 12300 nM
Estimate against measurement, compound 4: 1.2-fold (0.09 log units) below, within the range that was stated.
By their numbers in this assay, from the lowest: compound 2; then compounds 1, 3 and 4 (each within the scatter of the next).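

In this assay, the position on the aromatic carbon ortho to a chloro group now has its first isolated step, which reads a 1.4-fold higher number from compound 1 to compound 4 (0.15 log units; within the scatter) and stays within the scatter. Methoxycarbonyl, with 4 heavy atoms and 2 hydrogen-bond acceptors, can thus give way to methyl, with 1 heavy atom and no hydrogen-bond acceptor, without a readable change in growth inhibition on the background of compound 1, so neither the ester nor its acceptors are shown to be needed here in this series. No measured evidence bears on why the number holds under this change.

For the compounds shown here, only this one pair speaks for the position, so it remains open whether a carboxylic acid, an amine or a longer alkyl chain at the same carbon would also leave the number in place. Going by these compounds alone, it is also open whether the same change would give a similar step on the background of compound 2, the one compound whose number lies beyond the scatter from compound 1, though that gap spans more than one place and cannot be assigned to any single group.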